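A few compounds are considered here, and "the series" means these few. Any claim that something is new, unique, unknown or untested is made for them only; others in the source may bear on it.

Of the compounds shown here, three that share one core have been measured in a functional assay on A549 cells (Homo sapiens) for cytotoxicity, read by MTT assay, with a stated time of 24 h, tested at 40 uM; a higher number here means a weaker effect of the compound at the concentration tested, a lower number a stronger effect. Compound 1, `CCCCCCCCCCOC(=O)CCC(=O)N1CCN(CCCOc2cc3c(Nc4ccc(F)c(Cl)c4)ncnc3cc2OC)CC1`, gives 15.5%. Compound 2, `CCCCCCCCCCCOC(=O)CCC(=O)N1CCN(CCCOc2cc3c(Nc4ccc(F)c(Cl)c4)ncnc3cc2OC)CC1`, gives 12% in this assay. The difference between compound 1 and compound 2 is methyl in place of hydrogen on a saturated chain carbon, ten or more bonds along the chain from an oxygen next to a carbonyl group, and the resulting step is a number 3.5 percentage points lower from compound 1 to compound 2 (within the scatter). Compound 3, `CCCCCCCCCCCCCCCCCCCOC(=O)CCC(=O)N1CCN(CCCOc2cc3c(Nc4ccc(F)c(Cl)c4)ncnc3cc2OC)CC1`, gives 92.3% in this assay. It differs from compound 1 by nonyl in place of hydrogen on a saturated chain carbon, ten or more bonds along the chain from an oxygen next to a carbonyl group, and the step is a number 76.8 percentage points higher from compound 1 to compound 3 (beyond the scatter). Seen from compound 2 the step is a number 80.3 percentage points higher from compound 2 to compound 3 (beyond the scatter). Compound 3 thus stands highest of the three, with both of its steps to the others beyond the scatter.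

Compound 4, `CCCCCCCCCCCCCCCCCCCCOC(=O)CCC(=O)N1CCN(CCCOc2cc3c(Nc4ccc(F)c(Cl)c4)ncnc3cc2OC)CC1`, has not yet been measured. It differs from compound 3 by methyl in place of hydrogen on a saturated chain carbon, ten or more bonds along the chain from an oxygen next to a carbonyl group, the same change as that from compound 1 to compound 2, at a place described in the same words; among these compounds this change occurs twice. In the earlier instance the step was a number 3.5 percentage points lower from compound 1 to compound 2 (within the scatter), which stayed within the scatter.

Compound 4 is therefore expected to show a step of a number 2.3 percentage points lower from compound 3 to compound 4 (within the scatter), an expectation that rests on the matching step a number 3.5 percentage points lower from compound 1 to compound 2 (within the scatter) lying within the scatter and on compound 3 already standing near the top of the range at 92.3%. Compound 4 is estimated to give 90% in this assay, expected to fall between 78% and 100%.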

Compound 4, a percentage reported as activity, at one concentration (the size of the read-out at that concentration, not a potency): 87.1%
Estimate against measurement, compound 4: 2.9 percentage points above; low and high end bracket the measured number.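

In this assay the small change carried over from the shorter chain to the longer one, since methyl in place of hydrogen gave a number 5.2 percentage points lower from compound 3 to compound 4 (within the scatter), and the two instances agree: the same change on two cores in this assay, a number 3.5 percentage points lower (within the scatter) from compound 1 to compound 2 and a number 5.2 percentage points lower (within the scatter) from compound 3 to compound 4, 1.7 percentage points apart, within the scatter of two such steps The large change carried over as well, with nonyl in place of hydrogen giving a number 75.1 percentage points higher from compound 2 to compound 4 (beyond the scatter), a step that matches the earlier nonyl step: the same change on two cores in this assay, a number 76.8 percentage points higher (beyond the scatter) from compound 1 to compound 3 and a number 75.1 percentage points higher (beyond the scatter) from compound 2 to compound 4, 1.7 percentage points apart, within the scatter of two such steps The decyl change, a number 71.6 percentage points higher from compound 1 to compound 4 (beyond the scatter), has no second instance here, and the four compounds show transfer only for these two pairs of chains, so they do not show that a methyl step would stay this small on every chain, since the large steps show that chain length can matter greatly.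

The compounds shown leave open how the read-out runs for chains longer than that of compound 2 and shorter than that of compound 3, and whether a branched chain, or an amine or a carboxylic acid at the chain end, would follow the same steps. They also leave open whether these steps would hold on a different core or at another concentration.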